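The compounds below may be only part of what the source reports. "The series", "measured", "known", "first", "only" and "open" are said of these compounds alone.

Working notes on a diaryl urea series read in a functional assay on HepG2 cells (Homo sapiens) for inhibition, read by MTT assay, with a stated time of 120 h; a lower number here means a stronger inhibitor, a higher number a weaker inhibitor.

Three compounds have numbers. Compound 1 `CC(NC(=O)C#Cc1ccc(NC(=O)Nc2cc(C(F)(F)F)ccc2Cl)cc1)c1ccccc1` gives 19000 nM. Compound 2 `CC1CN(C(=O)c2ccc(-c3ccc(NC(=O)Nc4ccc(Cl)c(C(F)(F)F)c4)cc3)cc2)CC(C)O1` gives 31100 nM. Compound 3 `O=C(/C=C/c1ccc(NC(=O)Nc2ccc(Cl)c(C(F)(F)F)c2)cc1)NC1CCC1` gives 7510 nM, the lowest of the three, with compound 1 nearest and compound 2 furthest, both gaps beyond the scatter. No pair among these three differs in one place only, so no single change has yet been isolated.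

Compound 4 `CNC(=O)/C=C/c1ccc(NC(=O)Nc2ccc(Cl)c(C(F)(F)F)c2)cc1` has not been measured. It keeps the core of compound 3 and changes one thing: methyl in place of cyclobutyl on an amide-type nitrogen. Within the data shown here, no step between measured compounds speaks to this kind of change. In this assay the expectation for the move from compound 3 to compound 4 is a small loss, a 1.5-fold higher number from compound 3 to compound 4 (0.17 log units; within the scatter), a step that may not clear the scatter. For compound 4 the estimate in this assay is 11000 nM, expected to fall between 3500 nM and 35000 nM.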

Compound 4, half-maximal inhibitory concentration: 20400 nM
Estimate against measurement, compound 4: 1.9-fold (0.27 log units) below; measured number inside the range.
By their numbers in this assay, from the lowest: compound 3; then compounds 1, 4 and 2 (each within the scatter of the next).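

Among these compounds, this is the first single change isolated. On the amide-type nitrogen, methyl in place of cyclobutyl gives a 2.7-fold higher number from compound 3 to compound 4 (0.43 log units; beyond the scatter) in this assay, so the group at this position does affect the read-out, and of these two groups cyclobutyl goes with the lower number. Nothing at hand bears on why the number moves with this change.

With only two groups compared on this nitrogen, the compounds shown do not separate the presence of the ring from the carbon count, a question that ethyl, isopropyl or cyclopentyl could address, and a chain carrying an amine or a carboxylic acid remains a further unknown. From the compounds shown here alone, whether the same change would have a similar effect on the core of compound 1 also stays open.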